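This account rests on a few compounds, and the source may have more. Where it says the series, first, only, none or still open, it means among the compounds named here.

Of the compounds shown here, three sharing one core have been measured in a physicochemical assay for acid dissociation. Compound 2, `COc1cccc(CNCCCNc2ccnc3cc(Cc4ccccc4)ccc23)c1O`, gives 9.47. Compound 1, `CC(C)Cc1ccc2c(NCCCNCc3ccco3)ccnc2c1`, gives 9.47, and compound 3, `COc1ccc(F)cc1CNCCCNc1ccnc2cc(Cc3ccccc3)ccc12`, gives 9.47. Compound 2 thus stands level with compounds 1 and 3 at the digits shown, and nothing separates the three beyond the scatter. Among the measured compounds shown here, the one step that can be followed between measured compounds runs from compound 2 to compound 3, where 5-fluoro-2-methoxyphenyl replaces 2-hydroxy-3-methoxyphenyl on a saturated chain carbon bound to an amine nitrogen, and it reads no change at the digits printed from compound 2 to compound 3 (within the scatter).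

Compound 4, `COc1cccc(CNCCCNc2ccnc3cc(Cc4ccc(F)cc4Cl)ccc23)c1O`, has not yet been measured. It differs from compound 2 by 2-chloro-4-fluorophenyl in place of phenyl on a saturated chain carbon bound to an aromatic carbon. For the measured compounds named here, no measured step touches this group, so there is no direct precedent. Because the step from compound 2 to compound 3 read no change at the digits printed from compound 2 to compound 3 (within the scatter) for an exchange of one aromatic group for another, and the change in compound 4 is again such an exchange, on a saturated chain carbon bound to an aromatic carbon, the step from compound 2 to compound 4 is expected to be a number 0.02 log units lower from compound 2 to compound 4 (within the scatter), none beyond the scatter. For compound 4 in this assay the estimate is therefore 9.45, expected to lie between 9.15 and 9.75.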

Compound 4, acid dissociation constant: 9.47
The estimate for compound 4 lay 0.02 log units below the measured number; the range from low to high includes it.
By their numbers in this assay, from the lowest: compounds 1, 2, 3 and 4 (each within the scatter of the next).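

In this assay, among the compounds shown here, the exchange of phenyl for 2-chloro-4-fluorophenyl on a saturated chain carbon bound to an aromatic carbon gives no change at the digits printed from compound 2 to compound 4 (within the scatter), the first reading at this position, which no earlier step had touched. The read-out thus stays level when chlorine and fluorine enter this group together, adding to the phenyl ring without changing the count of hydrogen-bond donors or acceptors, just as it did for the change at the other end of compound 2, no change at the digits printed from compound 2 to compound 3 (within the scatter). No measurement shown here explains why the value holds at this position.

With the two halogens entering in a single step, the compounds shown cannot separate them, so 2-chlorophenyl and 4-fluorophenyl each remain open, and this one exchange says nothing about how a group of a different kind would read. A carboxylic acid or an amine on this aromatic ring, or a longer chain in place of the saturated chain carbon bound to it, could read differently in this assay, and nothing shown here settles whether it would.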